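Pyrrolidine to Dimethylamino on the Aryl Ether Chain

The source may report more compounds than this note shows. Statements on the series, on what has been measured and on what is new or still open speak of the compounds shown alone.

Compound 1 `CC(=O)SCC(=O)c1ccc(NS(=O)(=O)c2ccc(OCCc3ccccn3)cc2)nc1`: 750 nM
Compound 2 `CC(=O)SCC(=O)c1ccc(NS(=O)(=O)c2ccc(OCCCN3CCCC3)cc2)nc1`: 820 nM

Of the compounds shown here, two have been measured in a functional assay on HCT-116 cells (Homo sapiens) for cytotoxicity; a higher number here means that more compound is needed for the effect, a lower number that less compound is needed. Compound 1 gives 750 nM, and compound 2 gives 820 nM. Among the measured compounds shown here, the two numbers lie within the scatter of each other, so compound 2 cannot be set apart from compound 1 on these data; the only measured step, a 1.1-fold higher number from compound 1 to compound 2 (0.04 log units; within the scatter), shows that exchanging the group on the chain beyond the aryl ether oxygen left the read-out unmoved.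

Compound 3 `CC(=O)SCC(=O)c1ccc(NS(=O)(=O)c2ccc(OCCCCN(C)C)cc2)nc1` has not yet been measured. It differs from compound 2 in one place: (dimethylamino)methyl in place of pyrrolidin-1-yl on a saturated chain carbon, three bonds along the chain from an oxygen on an aromatic ring. For the measured compounds named here, the one step that bears on it, from compound 1 to compound 2, also swapped the terminal amine group on this chain and stayed within the scatter. For compound 3 the step is therefore expected to be a 1.0-fold higher number from compound 2 to compound 3 (0.02 log units; within the scatter), with no change beyond the scatter. Compound 3 is estimated at 850 nM, in the range 400 nM to 1800 nM.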

Compound 3, half-maximal effective concentration: 280 nM
For compound 3 the middle estimate is 3.0-fold (0.48 log units) above the measured one, outside the stated range (below it).
By their numbers in this assay, from the lowest: compound 3; then compounds 1 and 2 (each within the scatter of the next).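

In this assay, this position proves not to be indifferent to the group it carries: 4-(dimethylamino)butyl in place of 3-(pyrrolidin-1-yl)propyl gives a 2.9-fold lower number from compound 2 to compound 3 (0.47 log units; beyond the scatter), whereas the earlier exchange on this chain, a 1.1-fold higher number from compound 1 to compound 2 (0.04 log units; within the scatter), did not separate its two compounds. The 2-(dimethylamino)ethyl in place of pyridin-2-yl comparison points the same way, with a 2.7-fold lower number from compound 1 to compound 3 (0.43 log units; beyond the scatter), so compound 3 stands apart from both earlier compounds, by a modest margin in each case. Nothing available explains this difference.

The step changes the chain length and replaces the pyrrolidine ring with an open dimethylamino group at once, so the compounds shown cannot assign the shift to either change. A 4-(pyrrolidin-1-yl)butyl chain or a 3-(dimethylamino)propyl chain would separate the two, and a diethylamino end group would test how far the open amine can be varied.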